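A few compounds are considered here, and "the series" means these few. Any claim that something is new, unique, unknown or untested is made for them only; others in the source may bear on it.

Compound 2 `CC(=O)Oc1ccccc1C(=O)O[C@H]1CO[C@H]2[C@@H]1OC[C@H]2O` stands second highest of the three numbers in an ADME assay on a cell-free system (plasma, Homo sapiens) for metabolic stability, with Plasma (Rattus norvegicus) as the target, read by HPLC, at pH 7.4 (a higher number here means that the compound lasts longer, a lower number that the compound disappears faster), giving 0.055 h. Its nearest neighbour is compound 1 `CC(=O)Oc1ccccc1C(=O)O[C@H]1CO[C@H]2[C@@H]1OC[C@H]2OC(=O)c1ccccc1O`, which gives 0.0825 h, a gap within the scatter; its furthest is compound 3 `CC(=O)Oc1ccccc1C(=O)O[C@H]1CO[C@H]2[C@@H]1OC[C@H]2OC(=O)c1ccc(O)cc1`, which gives 0.0198 h. Compound 4 `CC(=O)Oc1ccccc1C(=O)O[C@H]1CO[C@H]2[C@@H]1OC[C@H]2OC(=O)c1ccccc1C` differs from compound 2 in one place: (2-methylphenyl)carbonyl in place of hydrogen on an oxygen on a saturated carbon. Going by the values given here, two measured steps bear on this change. One is the acylation of the same oxygen with a hydroxyphenyl-bearing group, which gave a 2.8-fold lower number from compound 2 to compound 3 (0.44 log units; beyond the scatter). The other is the reverse of the removal that gave a 1.5-fold lower number from compound 1 to compound 2 (0.18 log units; within the scatter), so the acyl group of compound 1 lies within the scatter of compound 2. The entering (2-methylphenyl)carbonyl shares its substitution pattern with the (2-hydroxyphenyl)carbonyl of compound 1 rather than with the (4-hydroxyphenyl)carbonyl of compound 3, so no step beyond the scatter is expected, with some chance of a lower number. Compound 4 is therefore estimated to give 0.055 h, with a range from 0.022 h to 0.13 h. This estimate means a step of no change at the digits printed from compound 2 to compound 4 (within the scatter), expected to stay within the scatter.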

Compound 4, half-life: 0.035 h
Beside the measured number, compound 4's estimate is 1.6-fold (0.20 log units) above it; measured number inside the range.
By their numbers in this assay, from the lowest: compounds 3, 4, 2 and 1 (each within the scatter of the next, the first and the last beyond it).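

In this assay, (2-methylphenyl)carbonyl on this oxygen gives a 1.6-fold lower number from compound 2 to compound 4 (0.20 log units; within the scatter), so this acyl group leaves the number within the scatter of the free hydroxy compound. Exchanging the aromatic group on the carbonyl carbon gives a 1.8-fold higher number from compound 3 to compound 4 (0.25 log units; within the scatter), also within the scatter, whereas methyl in place of hydroxy on an aromatic carbon gives a 2.4-fold lower number from compound 1 to compound 4 (0.37 log units; beyond the scatter), which is beyond it and shows that this single exchange on the acyl group can move the number measurably. No measured evidence accounts for these differences.

The compounds shown leave open how an acyl group carrying an amine or a carboxylic acid on its aromatic ring would behave at this oxygen. They also leave open what a longer chain in place of the aromatic ring would do.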